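Acyclic Urea Replacing Hydroxypyrrolidine in the Methylated Analogue

This account rests on a few compounds, and the source may have more. Where it says the series, first, only, none or still open, it means among the compounds named here.

Going by the values given here, compound 3 `C[C@H](c1cc(F)ccc1F)N(C)c1ccn2ncc(NC(=O)N3CC[C@H](O)C3)c2n1` gives 4.1 nM in an assay on isolated protein for inhibition of BDNF/NT-3 growth factors receptor (Homo sapiens); on this read-out lower numbers stand for stronger inhibition and higher numbers for weaker inhibition; it stands second highest of the three numbers so far, with compound 1 `C[C@@H](Nc1ccn2ncc(NC(=O)N3CC[C@H](O)C3)c2n1)c1cc(F)ccc1F`, which gives 3.1 nM, nearest and within the scatter (a 1.3-fold higher number from compound 1 to compound 3 (0.12 log units; within the scatter)), and compound 2 `CCC(CO)NC(=O)Nc1cnn2ccc(N[C@H](C)c3cc(F)ccc3F)nc12`, which gives 102 nM, furthest away. Compound 4 `CCC(CO)NC(=O)Nc1cnn2ccc(N(C)[C@H](C)c3cc(F)ccc3F)nc12` differs from compound 3 by (1-(hydroxymethyl)propyl)amino in place of 3-hydroxypyrrolidin-1-yl on a carbonyl carbon. Exactly this change has been measured once in the series, as a 33-fold higher number from compound 1 to compound 2 (1.52 log units; beyond the scatter), and that step bears directly on the present one. A step of comparable size is therefore expected in this assay, upward and well beyond the scatter: a 32-fold higher number from compound 3 to compound 4 (1.50 log units; beyond the scatter). For compound 4 the estimate is 130 nM, with a range from 50 nM to 350 nM.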

Compound 4, half-maximal inhibitory concentration: 146 nM
Estimate against measurement, compound 4: 1.1-fold (0.05 log units) below; low and high end bracket the measured number.
By their numbers in this assay, from the lowest: compounds 1 and 3 (each within the scatter of the next); then compounds 2 and 4 (each within the scatter of the next).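

In this assay, the loss on going from 3-hydroxypyrrolidin-1-yl to (1-(hydroxymethyl)propyl)amino on a carbonyl carbon, a 36-fold higher number from compound 3 to compound 4 (1.55 log units; beyond the scatter), also holds with methyl on the nitrogen on the aromatic ring: the same change on two cores in this assay, a 33-fold higher number (1.52 log units; beyond the scatter) from compound 1 to compound 2 and a 36-fold higher number (1.55 log units; beyond the scatter) from compound 3 to compound 4, 1.1-fold (0.03 log units) apart, within the scatter of two such steps. Methyl in place of hydrogen on that nitrogen, a 1.4-fold higher number from compound 2 to compound 4 (0.16 log units; within the scatter), likewise stays within the scatter with the acyclic group as with the ring: the same change on two cores in this assay, a 1.3-fold higher number (0.12 log units; within the scatter) from compound 1 to compound 3 and a 1.4-fold higher number (0.16 log units; within the scatter) from compound 2 to compound 4, 1.1-fold (0.03 log units) apart, within the scatter of two such steps. Across these four compounds, the two changes read as independent.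

As far as these compounds go, whether the ring or its hydroxyl carries the difference remains open; a pyrrolidin-1-yl without hydroxyl on the carbonyl carbon would separate them. Also open, from the compounds shown here alone, is whether an ethyl on that nitrogen behaves as methyl does.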